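Shortening the Chain of Compound 1

A few compounds are considered here, and "the series" means these few. Any claim that something is new, unique, unknown or untested is made for them only; others in the source may bear on it.

In a functional assay on DU-145 cells (Homo sapiens) for inhibition, read by MTT assay, with stated times of 18 h and 4 h (on this read-out lower numbers stand for stronger inhibition and higher numbers for weaker inhibition), compound 1 (`CCCCCCCCCCOP(=O)(O)OCCSC(=S)N1CCCCCC1`) gives 24000 nM and compound 2 (`CCCCCCCCCCOP(=O)(O)OCCSC(=S)N1CCCC1`) gives 46100 nM. Going by the values given here, these are the only two numbers so far, and they lie within the scatter of each other, so they cannot be told apart. Compound 3 (`CCCCCCCCOP(=O)(O)OCCSC(=S)N1CCCCCC1`) has not yet been measured. Its structure departs from compound 1 in one place: hydrogen in place of ethyl on a saturated chain carbon, eight bonds along the chain from an oxygen on an unsaturated carbon. In words, this is hydrogen in place of ethyl on a saturated chain carbon, eight bonds along the chain from an oxygen on an unsaturated carbon.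

Among the compounds with values here, the only measured step, a 1.9-fold higher number from compound 1 to compound 2 (0.28 log units; within the scatter), is a different change: pyrrolidin-1-yl in place of azepan-1-yl on a thiocarbonyl carbon. Within the data shown here, no measured pair alters the chain, so the direction of this new step is open, and that one small step is the only guide to its size. In this assay the expected step is a 1.5-fold higher number from compound 1 to compound 3 (0.16 log units; within the scatter), which stays within the scatter and is only a tentative lean towards a higher number. For compound 3 the estimated value is 35000 nM, with an expected range from 15000 nM to 80000 nM.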

Compound 3, half-maximal inhibitory concentration: 59100 nM
Compound 3: middle estimate off by 1.7-fold (0.23 log units), on the low side, and the stated range covers the measured number.
By their numbers in this assay, from the lowest: compounds 1, 2 and 3 (each within the scatter of the next, the first and the last beyond it).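

In this assay, placing hydrogen where ethyl stood on the saturated chain carbon, eight bonds along the chain from an oxygen on an unsaturated carbon, gives a 2.5-fold higher number from compound 1 to compound 3 (0.39 log units; beyond the scatter) and so a weaker result on this read-out. Going by these compounds alone, this modest step is the first here to clear the scatter, whereas the change on the thiocarbonyl carbon gave a 1.9-fold higher number from compound 1 to compound 2 (0.28 log units; within the scatter) and could not be told apart from repeat variation, so the chain position is the first place in this small set where a structural change can be read with some confidence. No measurement at hand explains why the number rises at this position.

From the compounds shown here alone, the step is a single comparison made with azepan-1-yl on the thiocarbonyl carbon, so it remains open whether the same change would have a similar effect with pyrrolidin-1-yl in that place. Also open, going by these compounds, is what a longer chain or a phenyl group at this chain carbon would do, which would show whether the trend continues in the other direction or depends on the kind of group placed there.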